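Substituent swaps on the shared core: outlook for compound 4

The source may hold more compounds than are shown below. What is called first, only, known or untested is meant among the compounds shown, and "the series" means these compounds.

Compound 1 `CC(C)(C)c1cn(C[C@H](O)[C@H]2OC(=O)C(OCc3ccccc3)=C2OCc2ccccc2)nn1` — in a functional assay on HeLa cells (Homo sapiens) for antiproliferative activity, read by MTT assay, with a stated time of 72 h (a lower number here means a stronger inhibitor, a higher number a weaker inhibitor), compound 1 gives 18300 nM.
Compound 2 `Cc1ccc(S(=O)(=O)NCc2cn(C[C@H](O)[C@H]3OC(=O)C(OCc4ccccc4)=C3OCc3ccccc3)nn2)cc1` — compound 2 gives 14400 nM.
Compound 3 `COc1ccc(-c2cn(C[C@H](O)[C@H]3OC(=O)C(OCc4ccccc4)=C3OCc3ccccc3)nn2)cc1` — compound 3 gives 16400 nM.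

Compound 1 has the highest number of the three, but neither gap separates it from the others: a 1.3-fold lower number from compound 1 to compound 2 (0.10 log units; within the scatter) and a 1.1-fold lower number from compound 1 to compound 3 (0.05 log units; within the scatter) both sit within the scatter. Compound 4 `O=C1O[C@H]([C@@H](O)Cn2cc(CCO)nn2)C(OCc2ccccc2)=C1OCc1ccccc1` differs from compound 1 as 2-hydroxyethyl in place of tert-butyl on an aromatic carbon. The two measured steps bear directly on this change, since each replaces the tert-butyl group on the same aromatic carbon of the shared core, and both stayed within the scatter. Accordingly no movement beyond the scatter is expected from compound 1 to compound 4: a 1.1-fold lower number from compound 1 to compound 4 (0.03 log units; within the scatter). Compound 4 is estimated at 17000 nM, with a range of 8000 nM to 36000 nM.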

Compound 4, half-maximal inhibitory concentration: 68800 nM
Compound 4: middle estimate off by 4.0-fold (0.61 log units), on the low side; the measured number lies above the stated range.
By their numbers in this assay, from the lowest: compounds 2, 3 and 1 (each within the scatter of the next); then compound 4.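

Among the compounds shown here, of the groups seen on this aromatic carbon, 2-hydroxyethyl is the first to move the number beyond the scatter (a 3.8-fold higher number from compound 1 to compound 4 (0.58 log units; beyond the scatter)) and (a 4.2-fold higher number from compound 3 to compound 4 (0.62 log units; beyond the scatter)), whereas the three earlier groups stayed within it. Hydroxymethyl in place of ((4-methylphenyl)sulfonyl)amino on the chain carbon points the same way (a 4.8-fold higher number from compound 2 to compound 4 (0.68 log units; beyond the scatter)). Nothing available here bears on what lies behind this rise.

From the compounds shown here alone, whether it follows the hydroxyl or the shorter chain stays open; an ethyl group, a longer hydroxyalkyl chain, an amine or a carboxylic acid on this carbon would help separate the two.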